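Ethyl ester of compound 1 in the cytotoxicity read-out

The source may hold more compounds than are shown below. What is called first, only, known or untested is meant among the compounds shown, and "the series" means these compounds.

Compound 1 `CC(C)COc1cccc(-c2ccc(C(=O)N(Cc3cccc(OCCCCCC(=O)O)c3)C(C)C)cc2)c1` is the reference point. In an ADME assay on HepG2 cells (Homo sapiens) for cytotoxicity, read by CellTiter-Glo and resazurin assay, with a stated time of 72 h (a lower number here means that less compound is needed, a higher number that more compound is needed for the effect), compound 1 gives > 26000 nM, which is a limit of the assay and not a number. Compound 2 `COc1cc(OC)cc(-c2ccc(C(=O)N(Cc3cccc(OCCCCCC(=O)O)c3)C(C)C)cc2)c1` sits at a limit as well: in this assay compound 2 gives > 26000 nM. Compound 3 `CC(C)N(Cc1cccc(OCCCCCC(=O)O)c1)C(=O)c1ccc(-c2cccc(S(C)(=O)=O)c2)cc1` is no different in kind; in this assay compound 3 gives > 26000 nM, again a limit. As a result the measured steps a step that the two limits leave unreadable from compound 1 to compound 2, a step that the two limits leave unreadable from compound 1 to compound 3 and a step that the two limits leave unreadable from compound 2 to compound 3 cannot be sized; all that can be said is the limit of > 26000 nM in this assay, at which 3 of the 3 values shown sit.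

Compound 4 `CCOC(=O)CCCCCOc1cccc(CN(C(=O)c2ccc(-c3cccc(OCC(C)C)c3)cc2)C(C)C)c1` differs from compound 1 by ethyl in place of hydrogen on an oxygen next to a carbonyl group. None of the three measured steps touches the acid end of the chain; each of them exchanges a group on an aromatic carbon of the outer ring, and each is unreadable anyway. Going by the values given here, no measured step therefore bears on the change to compound 4, and the only guidance is that every value so far sits at the same limit. The expectation for compound 4 is that it also reaches that limit, with the step from compound 1 expected as a step that the limit leaves unreadable from compound 1 to compound 4, no step beyond scatter. The estimate for compound 4 in this assay is 30000 nM, expected to lie between 15000 nM and 60000 nM.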

Compound 4, half-maximal effective concentration: > 26000 nM
Compound 4 ended at the assay's limit (the forecaster's own chance of this, stated with the estimate: 75%); the middle value is on the limit's open side.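

Compound 1 and compound 4 both sit at a limit of the assay, so ethyl in place of hydrogen on the oxygen next to the carbonyl group gives no readable step. The compounds shown leave open whether any change to the shared core brings a value off that limit, and the only reading remains: the limit of > 26000 nM in this assay, at which 4 of the 4 values shown sit.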